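Replacing an acetyl with a chlorobenzoyl group

The source may hold more compounds than are shown below. What is called first, only, known or untested is meant among the compounds shown, and "the series" means these compounds.

Compound 3 `CC(=O)N1c2ccccc2CCC1C(=O)Nc1ccccc1C(F)(F)F` sits at the top of the numbers shown: in a functional assay on NUGC-3 cells (Homo sapiens) for cytotoxicity, read by sulforhodamine B assay, with a stated time of 72 h (a higher number here means a weaker inhibitor of growth, a lower number a stronger inhibitor of growth), compound 3 gives > 80000 nM, which is a limit of the assay rather than a measured number. Compound 4 `O=C(Nc1ccccc1C(F)(F)F)C1CCc2ccccc2N1C(=O)c1ccccc1Cl` carries 2-chlorophenyl in place of methyl on a carbonyl carbon. Among the compounds with values here, two measured steps bear on this change. Compound 1 `O=C(Nc1ccccc1C(F)(F)F)C1CCc2ccccc2N1C(=O)c1cccc(Cl)c1` gives 754 nM in this assay, and compound 2 `O=C(Nc1ccccc1C(F)(F)F)C1CCc2ccccc2N1C(=O)c1ccc(Cl)cc1` gives 551 nM; read the other way, an at least 100-fold higher number from compound 1 to compound 3 (2.02 log units; beyond the scatter) and an at least 140-fold higher number from compound 2 to compound 3 (2.16 log units; beyond the scatter). Compound 4 differs from compound 1 and compound 2 only in the chlorophenyl group, so a large fall in the number is expected, an at least 110-fold lower number from compound 3 to compound 4 (2.05 log units; beyond the scatter). Compound 4 is therefore estimated at 700 nM, with a range from 250 nM to 2500 nM.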

Compound 4, concentration for 50% growth inhibition: 2730 nM
Estimate against measurement, compound 4: 3.9-fold (0.59 log units) below, outside the stated range (above it).
By their numbers in this assay, from the lowest: compounds 2 and 1 (each within the scatter of the next); then compound 4. At a limit, above all of these: compound 3.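

In this assay, 2-chlorophenyl on this carbonyl carbon still gives an at least 29-fold lower number from compound 3 to compound 4 (1.46 log units; beyond the scatter), so this gain over methyl is not confined to the 3-chlorophenyl and 4-chlorophenyl groups. This step is only a bound, set by the limit for compound 3: the limit of > 80000 nM in this assay, at which 1 of the 4 values shown sits. The placing of the chlorine also counts, which compound 1 and compound 2 alone, within the scatter of each other, could not show: there is a 5.0-fold higher number from compound 2 to compound 4 (0.70 log units; beyond the scatter) and a 3.6-fold higher number from compound 1 to compound 4 (0.56 log units; beyond the scatter).

On these data alone, whether the chlorine itself is needed remains open. A fluorine or a methoxy group on the phenyl ring, or a plain unsubstituted phenyl, could settle that.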